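Adding a Fluoro Group to Compound 2

This account rests on a few compounds, and the source may have more. Where it says the series, first, only, none or still open, it means among the compounds named here.

In a functional assay on Vero cells (Chlorocebus sabaeus) for cytotoxicity (on this read-out higher numbers stand for weaker inhibition and lower numbers for stronger inhibition), compound 1 `O=c1ccn(C2C=C(F)C(CO)O2)c(=O)[nH]1` gives 82600 nM as a measured number. Compound 2 `Nc1ccn([C@H]2C=C(F)[C@@H](CO)O2)c(=O)n1` stands at > 100000 nM as a limit of the assay and not a number. Among the measured compounds shown here, that leaves the limit of > 100000 nM in this assay, at which 1 of the 2 values shown sits, and no measured step to go by. Compound 3 `Nc1nc(=O)n([C@H]2C=C(F)[C@@H](CO)O2)cc1F` differs from compound 2 by a single change fluoro in place of hydrogen on an aromatic carbon in which fluoro takes the place of hydrogen on an aromatic carbon, ortho to an amino group. Only a small step toward stronger inhibition is expected in this assay and perhaps none beyond the usual scatter. The expected size of the change is an at least 1.2-fold lower number from compound 2 to compound 3 (0.09 log units; that floor lies within the scatter) on this estimate. Compound 3 is estimated at 80000 nM with an expected range of 20000 nM to 150000 nM, and a limit of the assay in place of a number may also be expected.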

Compound 3, half-maximal inhibitory concentration: > 100000 nM
Compound 3 ended at the assay's limit; the forecaster's own chance of this, stated with the estimate: 60%; middle value at least 1.2-fold (0.09 log units) away from the limit.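

Compound 2 and compound 3 both stand at a limit of this assay rather than at a number, so no step can be read between them: the limit of > 100000 nM in this assay, at which 2 of the 3 values shown sit.

The compounds shown leave open whether fluoro in place of hydrogen on an aromatic carbon changes the result in this assay at all.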